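Cyclohexyl for isopropyl on the shared core

The source may report more compounds than this note shows. Statements on the series, on what has been measured and on what is new or still open speak of the compounds shown alone.

In an assay on membranes from HEK293 cells for displacement of a labelled ligand from Type-2 angiotensin II receptor (Homo sapiens), read by radioligand binding (on this read-out lower numbers stand for stronger inhibition and higher numbers for weaker inhibition), compound 1 `CCCCOC(=O)NS(=O)(=O)c1ccc(CCC)cc1-c1ccc(Cn2c(C(C)C)nc3ccccc32)cc1` gives 4 nM. Compound 2 `CCCc1ccc(S(=O)(=O)NC(=O)OCCC(F)(F)C(F)(F)F)c(-c2ccc(Cn3c(C(C)(C)C)nc4ccccc43)cc2)c1` gives 6 nM in this assay, and the two values sit within the scatter of each other. Compound 3 `CCCCOC(=O)NS(=O)(=O)c1ccc(CCC)cc1-c1ccc(Cn2c(C3CCCCC3)nc3ccccc32)cc1` is not yet measured. It differs from compound 1 in one place: cyclohexyl in place of isopropyl on an aromatic carbon. Among the measured compounds shown here, no step between measured compounds covers this change; compound 2 carries a bulkier group at the same place and its value stays within the scatter of compound 1, so the expected step of a 1.5-fold higher number from compound 1 to compound 3 (0.18 log units; within the scatter) is none beyond the scatter. Compound 3 is estimated at 6 nM, range 2 nM to 20 nM.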

Compound 3, inhibition constant: 130 nM
Estimate against measurement, compound 3: 22-fold (1.34 log units) below; the measured number lies above the stated range.
By their numbers in this assay, from the lowest: compounds 1 and 2 (each within the scatter of the next); then compound 3.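

In this assay, the aromatic carbon between two ring nitrogen atoms proves sensitive to the group it carries: cyclohexyl in place of isopropyl gives a 33-fold higher number from compound 1 to compound 3 (1.51 log units; beyond the scatter), a large step and the first single change read at this position. Adding carbon here as a six-membered ring therefore weakens inhibition on the core of compound 1. Nothing measured here accounts for the step.

Still open, going by these compounds, is whether the ring itself or the added carbon count goes with the step. A cyclopropyl ring or an open pentyl chain on the same carbon of the shared core would separate the two.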